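This account rests on a few compounds, and the source may have more. Where it says the series, first, only, none or still open, it means among the compounds named here.

Compound 1 `Nc1ncnc2c1ncn2[C@@H]1O[C@@]2(CO)CO[C@@H]1[C@@H]2O` gives in a functional assay for agonist activity at adenosine receptor A3 (Homo sapiens), with a stated time of 30 min (a lower number here means that less compound is needed, a higher number that more compound is needed for the effect), a limit of > 100000 nM.
Compound 2 `CNC(=O)[C@@]12CO[C@@H]([C@H](n3cnc4c(NCc5cccc(I)c5)ncnc43)O1)[C@@H]2O` gives in this assay a limit of > 100000 nM.
Compound 3 `CNC(=O)[C@@]12CN[C@@H]([C@H](n3cnc4c(N)ncnc43)O1)[C@@H]2O` gives in this assay a limit of > 100000 nM.

Compound 3 therefore stands where all three measured compounds stand, at the limit of > 100000 nM in this assay, at which 3 of the 3 values shown sit, with no number that would rank it against the others. Compound 4 `CNC(=O)[C@@]12CN[C@@H]([C@H](n3cnc4c(NCc5cccc(I)c5)ncnc43)O1)[C@@H]2O` differs from compound 3 by 3-iodobenzyl in place of hydrogen on a nitrogen on an aromatic ring. For the measured compounds named here, no step between measured compounds is recorded, so the size of this change in this assay can only be expected, not read off. Compound 2 carries the same 3-iodobenzyl group on the same kind of nitrogen and also sits at a limit, which gives no sign that this group moves a compound of this core off the limit. Compound 4 is therefore expected to stay at or near the limit, with the step estimated as a number no higher from compound 3 to compound 4 (the limit leaves the size open). The estimated value of compound 4 is 100000 nM, within a range from 10000 nM to 300000 nM.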

Compound 4, half-maximal effective concentration: > 100000 nM
Compound 4: only a limit was reported (the forecaster's own chance of this, stated with the estimate: 70%); the middle value sits exactly at the limit.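

Compound 3 and compound 4 both sit at a limit in this assay, so no step between them can be read: the limit of > 100000 nM in this assay, at which 4 of the 4 values shown sit.

The compounds shown leave open what effect, if any, 3-iodobenzyl has on the nitrogen, and whether any of them would give a readable value in this assay.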